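This account rests on a few compounds, and the source may have more. Where it says the series, first, only, none or still open, it means among the compounds named here.

Compound 3 `CCc1nncn1-c1ccc(OCc2ccc(C)cc2)cc1` gives 25.5 mg/kg in a functional assay on the whole organism (strain C57B/6) with Mus musculus as the target, in the maximal electroshock model; a higher number here means that more compound is needed for the effect, a lower number that less compound is needed. Compound 1 `CCc1nncn1-c1ccc(OCc2ccc(F)cc2)cc1` gives 22.8 mg/kg in this assay, and compound 2 `CCc1nncn1-c1ccc(OCc2ccc(Cl)cc2)cc1` gives 19.7 mg/kg. Compound 3 has the highest number of the three, yet every step among them stays inside the scatter: a 1.1-fold higher number from compound 1 to compound 3 (0.05 log units; within the scatter) and a 1.3-fold higher number from compound 2 to compound 3 (0.11 log units; within the scatter), with a 1.2-fold lower number from compound 1 to compound 2 (0.06 log units; within the scatter). Compound 4 `CCCCCCCOc1ccc(-n2cnnc2CC)cc1` differs from compound 3 by hexyl in place of 4-methylphenyl on a saturated chain carbon bound to an oxygen on an aromatic ring. Going by the values given here, no measured step exchanges the aromatic ring of the side chain for a saturated chain; the three measured steps only swap one small group on that ring and all sit inside the scatter, so they give no direction for this change. The step from compound 3 to compound 4 is therefore estimated only loosely, as a 1.4-fold higher number from compound 3 to compound 4 (0.14 log units; within the scatter). Compound 4 is expected to give about 35 mg/kg in this assay, within a range from 14 mg/kg to 90 mg/kg.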

Compound 4, dose for half-maximal effect: 8.3 mg/kg
Beside the measured number, compound 4's estimate is 4.2-fold (0.62 log units) above it; the measured number lies below the stated range.
By their numbers in this assay, from the lowest: compound 4; then compounds 2, 1 and 3 (each within the scatter of the next).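

Swapping the substituted aromatic ring on this saturated chain carbon for hexyl does what no swap of the small group on that ring did: it moves the number beyond the scatter in this assay (a 3.1-fold lower number from compound 3 to compound 4 (0.49 log units; beyond the scatter); a 2.4-fold lower number from compound 2 to compound 4 (0.38 log units; beyond the scatter); a 2.7-fold lower number from compound 1 to compound 4 (0.44 log units; beyond the scatter)). At this position, then, less compound is needed with the open chain than with any of the three ring-bearing side chains. Nothing available explains why this change lowers the number. Going by these compounds, whether a shorter chain such as butyl or a longer one such as octyl would give a similar number remains open. So does the effect of an amine or a carboxylic acid at the end of the chain.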